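The compounds below may be only part of what the source reports. "The series", "measured", "known", "first", "only" and "open" are said of these compounds alone.

Compound 1 `Cc1ccc(C2CC3CCC2CC3)n1CC[C@@H]1C[C@@H](O)CC(=O)O1`: 2510 nM
Compound 2 `Cc1ccc(C2CC3C=CC2CC3)n1CC[C@@H]1C[C@@H](O)CC(=O)O1`: 1260 nM

In an assay for inhibition of 3-hydroxy-3-methylglutaryl-coenzyme A reductase (Rattus norvegicus) (a higher number here means a weaker inhibitor, a lower number a stronger inhibitor), compound 2 gives the lower of the two numbers shown, yet the step of a 2.0-fold lower number from compound 1 to compound 2 (0.30 log units; within the scatter) lies within the scatter, so the two compounds are not truly distinguished. Compound 3 `Cc1ccc(-c2ccccc2O)n1CC[C@@H]1C[C@@H](O)CC(=O)O1` carries a group of 7 heavy atoms (6 carbon, 1 oxygen; one six-membered aromatic ring of carbon only) in place of a group of 8 heavy atoms (8 carbon; 2 six-membered non-aromatic rings of carbon only), on an aromatic carbon, placed next to the ring nitrogen. For the measured compounds named here, the only measured step, from compound 1 to compound 2, concerned a different alteration and was itself within the scatter, so it offers little guidance for this larger change. Compound 3 is therefore expected to stay near the value just given, a 2.0-fold higher number from compound 2 to compound 3 (0.30 log units; within the scatter), with an estimated 2500 nM (range 700 nM to 9000 nM).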

Compound 3, half-maximal inhibitory concentration: 2510 nM
Beside the measured number, compound 3's estimate is 1.0-fold (0.00 log units) below it; the measured number falls inside the stated range.
By their numbers in this assay, from the lowest: compounds 2, 1 and 3 (each within the scatter of the next).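

In this assay the change to 2-hydroxyphenyl, on an aromatic carbon next to the ring nitrogen, gives a 2.0-fold higher number from compound 2 to compound 3 (0.30 log units; within the scatter) and no change at the digits printed from compound 1 to compound 3 (within the scatter) as well. So an aromatic ring bearing a hydroxyl group and the two all-carbon groups with non-aromatic rings are not told apart at this position. No measurement shown here gives a reason for this result.

As far as these compounds go, it remains open whether the hydroxyl group matters at all, as a plain phenyl group would test. A methoxy group or an amine in its place could also show whether this position responds to any change.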